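Fluoro in place of methyl on compound 2

The compounds below may be only part of what the source reports. "The series", "measured", "known", "first", "only" and "open" are said of these compounds alone.

Measured in a functional assay on OVCAR-3 cells (Homo sapiens) for antiproliferative activity, read by MTT assay, with a stated time of 24 h; a lower number here means a stronger inhibitor, a higher number a weaker inhibitor
compound 1 `O=C(NNc1ccccc1Cl)c1ccc(NS(=O)(=O)c2cnc(O)nc2O)cc1` gives 7230 nM
compound 2 `Cc1ccccc1NNC(=O)c1cccc(NS(=O)(=O)c2cnc(O)nc2O)c1` gives > 20000 nM

For compound 2 the reading (> 20000 nM) is a limit and not a number. That leaves compound 2 with no exact place in the series (the limit of > 20000 nM in this assay, at which 1 of the 2 values shown sits). Only compound 1 has a number (7230 nM).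

Compound 3 `O=C(NNc1ccccc1F)c1cccc(NS(=O)(=O)c2cnc(O)nc2O)c1` carries fluoro in place of methyl on an aromatic carbon of compound 2, ortho to a large group (fluoro in place of methyl on an aromatic carbon). Going by the values given here, no measured step shows what this exchange does in this assay, so no shift beyond the scatter is expected, and a further limit reading would be no surprise. The expected step is small and slightly towards a stronger inhibitor (an at least 1.1-fold lower number from compound 2 to compound 3 (0.04 log units; that floor lies within the scatter)). The estimate for compound 3 is 18000 nM (expected range 8000 nM to 35000 nM).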

Compound 3, half-maximal inhibitory concentration: 17000 nM
Beside the measured number, compound 3's estimate is 1.1-fold (0.02 log units) above it; low and high end bracket the measured number.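

In this assay, fluoro in place of methyl on the ring gives an at least 1.1-fold lower number from compound 2 to compound 3 (0.07 log units; that floor lies within the scatter). That step has only a floor because compound 2 is read at a limit: the limit of > 20000 nM in this assay, at which 1 of the 3 values shown sits. Going by these compounds alone, compound 3 thus gives the 2-fluorophenyl compound an exact reading where the 2-methylphenyl compound has none, so later exchanges at this place can be read against a number, while compound 1 differs from compound 3 in more than one place and gives no step here.

On these data alone, how far compound 2 truly lies from compound 3 stays open, so it cannot be said whether this exchange does anything beyond the scatter. Also open, as far as these compounds go, is how an amine, a methoxy group or a carboxylic acid would read in place of fluoro on compound 3.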